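The source may report more compounds than this note shows. Statements on the series, on what has been measured and on what is new or still open speak of the compounds shown alone.

Measured in a functional assay on A-431 cells (Homo sapiens) for inhibition, read by MTT assay, with a stated time of 72 h; a higher number here means a weaker inhibitor, a lower number a stronger inhibitor:
- Compound 1 `O=[N+]([O-])c1ccc(-c2nnc(SCCCN3CCN(c4nc5ccccc5o4)CC3)o2)cc1`: 46900 nM
- Compound 2 `Fc1ccc(-c2nnc(SCCCN3CCN(c4nc5ccccc5o4)CC3)o2)cc1`: 136000 nM
- Compound 3 `Brc1ccc(-c2nnc(SCCCN3CCN(c4nc5ccccc5o4)CC3)o2)cc1`: 57800 nM

Compound 1 stands in the lower pair of these three numbers, with a 1.2-fold higher number from compound 1 to compound 3 (0.09 log units; within the scatter) and a 2.9-fold higher number from compound 1 to compound 2 (0.46 log units; beyond the scatter). The next compound to be tested, compound 4 `O=C(NCc1nnc(SCCCN2CCN(c3nc4ccccc4o3)CC2)o1)c1ccccc1`, keeps the shared core but carries benzamidomethyl in place of 4-nitrophenyl on an aromatic carbon of the five-membered aromatic ring: benzamidomethyl in place of 4-nitrophenyl on an aromatic carbon.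

The measured steps bear on this change only indirectly. They exchange nitro, fluoro and bromo on an aromatic carbon, and the aromatic ring carrying them stays in place. The largest are a 2.9-fold higher number from compound 1 to compound 2 (0.46 log units; beyond the scatter) and a 2.4-fold lower number from compound 2 to compound 3 (0.37 log units; beyond the scatter), both modest. Going by the values given here, no measured step replaces the whole 4-nitrophenyl group, so the data give no direct guide to the size or direction of this one, and any expectation is loose.

With compound 1 already in the lower pair, a modest move towards a higher number is the more likely outcome, similar in size to the largest measured step. The estimate is a 2.1-fold higher number from compound 1 to compound 4 (0.33 log units; beyond the scatter). Compound 4 is expected at 100000 nM, with an estimated range of 35000 nM to 250000 nM.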

Compound 4, half-maximal inhibitory concentration: 36900 nM
The estimate for compound 4 lay 2.7-fold (0.43 log units) above the measured number; measured number inside the range.
By their numbers in this assay, from the lowest: compounds 4, 1 and 3 (each within the scatter of the next); then compound 2.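

In this assay, going by these compounds alone, this carbon of the five-membered aromatic ring tolerates a far larger exchange than the earlier compounds tested: the whole 4-nitrophenyl group can give way to benzamidomethyl, which brings in an amide hydrogen, with a 1.3-fold lower number from compound 1 to compound 4 (0.10 log units; within the scatter). The replacement of 4-bromophenyl likewise stays within the scatter, with a 1.6-fold lower number from compound 3 to compound 4 (0.19 log units; within the scatter), and only the replacement of 4-fluorophenyl gives a change beyond it, with a 3.7-fold lower number from compound 2 to compound 4 (0.57 log units; beyond the scatter), so among these four compounds an aromatic ring attached directly to this carbon is not required to reach the level of compound 1. No measurement available here explains why the exchange is tolerated.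

Going by these compounds, it remains open which part of benzamidomethyl matters, and whether a simple amine, a carboxylic acid or a longer chain at this carbon would hold the number at this level or shift it. On these data alone, the shared core is the same in all four compounds, so what its other parts contribute in this assay also remains open.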